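Triazolyl urea series: meta-cyano on the phenyl urea

This account rests on a few compounds, and the source may have more. Where it says the series, first, only, none or still open, it means among the compounds named here.

Measured so far:
compound 1, `Cc1ccsc1CN(C(=O)Nc1ccccc1)n1cnnc1`, > 50000 nM in a functional assay on MDA-MB-231 cells (Homo sapiens) for cytotoxicity, read by MTT assay, with a stated time of 48 h (on this read-out higher numbers stand for weaker inhibition and lower numbers for stronger inhibition), a limit of the assay
compound 2, `N#Cc1ccc(CN(C(=O)Nc2ccccc2)n2cnnc2)cc1`, > 50000 nM in this assay, a limit of the assay

Compound 1 stands only at a limit in this assay; compound 2 sits at the same limit, and the step that the two limits leave unreadable from compound 1 to compound 2 is therefore unreadable. Within the data shown here, both values rest on (the limit of > 50000 nM in this assay, at which 2 of the 2 values shown sit), so no measured step has a readable size.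

Compound 3, `Cc1ccsc1CN(C(=O)Nc1cccc(C#N)c1)n1cnnc1`, differs from compound 1 by cyano in place of hydrogen on an aromatic carbon. Among the measured compounds shown here, no measured step touches the phenyl urea side of the core, and the only step known, from compound 1 to compound 2, gives no size. The working expectation is that compound 3 stays near the limit and that a step that the limit leaves unreadable from compound 1 to compound 3 is no more than scatter. Compound 3 is estimated at 60000 nM in this assay, within 15000 nM to 250000 nM, most likely reported again as a limit.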

Compound 3, half-maximal inhibitory concentration: > 50000 nM
Compound 3: only a limit was reported (the forecaster's own chance of this, stated with the estimate: 80%); the middle value is on the limit's open side.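

Compound 1 and compound 3 both stand only at a limit, so the step between them cannot be read: (the limit of > 50000 nM in this assay, at which 3 of the 3 values shown sit).

The compounds shown leave open whether any change to the shared core gives a readable value in this assay rather than a limit.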